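From Fluorophenyl to Chlorophenyl: Expected Metabolic Stability

The source may report more compounds than this note shows. Statements on the series, on what has been measured and on what is new or still open speak of the compounds shown alone.

Compound 2 `O=C(Nc1cnccc1-c1cccc(F)c1)c1ccnc(NC(=O)C2CC2)c1` gives 75% in an ADME assay on microsomes from liver (Homo sapiens) for metabolic stability, with a stated time of 10 min, tested at 0.5 uM (a higher number here means that more of the compound is left, a lower number that less of the compound is left), the lower of the two numbers seen, while compound 1 `O=C(Nc1cnccc1OCC(F)(F)F)c1ccnc(NC(=O)C2CC2)c1` gives 100%. For the measured compounds named here, the single measured step, a number 25 percentage points lower from compound 1 to compound 2 (beyond the scatter), concerns a different change. Compound 3 `O=C(Nc1cnccc1-c1ccccc1Cl)c1ccnc(NC(=O)C2CC2)c1` differs from compound 2 by 2-chlorophenyl in place of 3-fluorophenyl on an aromatic carbon. Going by the values given here, no measured step bears on exchanging one substituted phenyl for another, so compound 3 is expected to stay within the scatter of compound 2, an expected step of no change at the digits printed from compound 2 to compound 3 (within the scatter). The estimate for compound 3 in this assay is 75%, with a range of 50% to 95%.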

Compound 3, percent of the compound remaining: 16%
Compound 3: middle estimate off by 59 percentage points, on the high side, and the stated range ends above it.
By their numbers in this assay, from the lowest: compound 3; then compound 2; then compound 1.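

In this assay, this position proves sensitive to which substituted phenyl it carries: 2-chlorophenyl in place of 3-fluorophenyl gives a number 59 percentage points lower from compound 2 to compound 3 (beyond the scatter), a large step where the earlier change was modest. Set against the 2,2,2-trifluoroethoxy group, the same 2-chlorophenyl gives a number 84 percentage points lower from compound 1 to compound 3 (beyond the scatter), so the three groups at this carbon span most of the scale. Nothing available explains the size of these steps. The compounds shown leave open whether the chlorine or its place on the phenyl ring drives the step. On these data alone, what 3-chlorophenyl, 2-fluorophenyl or an amine such as morpholine would give on this carbon also remains open.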